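Inverting One More Stereocentre in the Shared Core

The source may report more compounds than this note shows. Statements on the series, on what has been measured and on what is new or still open speak of the compounds shown alone.

Compound 1 `O=C(O)[C@H]1NC[C@@H](O)[C@H](O)[C@H]1O`: 6.3%
Compound 2 `O=C(O)[C@@H]1NC[C@@H](O)[C@@H](O)[C@H]1O`: 26%

Of the compounds shown here, two have been measured in an assay on isolated protein for inhibition of cytosolic endo-beta-N-acetylglucosaminidase (Homo sapiens), tested at 1000 uM; on this read-out higher numbers stand for more inhibition at the one concentration tested (going by the name of the read-out) and lower numbers for less inhibition. Compound 1 `O=C(O)[C@H]1NC[C@@H](O)[C@H](O)[C@H]1O` gives 6.3%, while compound 2 `O=C(O)[C@@H]1NC[C@@H](O)[C@@H](O)[C@H]1O` gives 26%. For the measured compounds named here, compound 2 stands highest of the two numbers, with compound 1 as its only neighbour, and the step between them is a number 19.7 percentage points higher from compound 1 to compound 2 (beyond the scatter), a modest rise that rests on (the fact that compounds 1 and 2 differ only in the configuration as drawn).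

Compound 3 `O=C(O)[C@@H]1NC[C@@H](O)[C@@H](O)[C@@H]1O` has not yet been measured. It differs from compound 2 in this way: the two compounds have the same atoms and bonds and differ only in configuration as drawn: 1 of 4 stereo elements differ; a stereocentre at a saturated ring carbon is drawn S in compound 2 and R in compound 3. Going by the values given here, the one measured step that bears on this change is the same kind of step, a change of configuration alone, and it was a number 19.7 percentage points higher from compound 1 to compound 2 (beyond the scatter) in size; it altered two stereo elements, however, where the present change alters one, and it gives no direction for a single inversion on its own. A move of either sign is therefore possible, and the most defensible expectation is a small one. For compound 3 the estimated value in this assay is 20%, within a range from 3% to 50%. The estimated step is a number 6 percentage points lower from compound 2 to compound 3 (within the scatter), a change not expected to exceed the scatter.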

Compound 3, a percentage reported as inhibition, at one concentration (the size of the read-out at that concentration, not a potency): 2.1%
For compound 3 the middle estimate is 17.9 percentage points above the measured one; measured number outside the range, below it.
By their numbers in this assay, from the lowest: compounds 3 and 1 (each within the scatter of the next); then compound 2.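

Inverting this one ring stereocentre is enough on its own to move the number in this assay: the change gives a number 23.9 percentage points lower from compound 2 to compound 3 (beyond the scatter) and so shows that the configuration at this single carbon matters for the inhibition seen. The earlier pair altered two stereo elements together, whereas here one inversion stands alone with nothing entering or leaving, so the drop can be laid to configuration alone: the fact that compounds 2 and 3 differ only in the configuration as drawn. The rise seen in compound 2 is also not kept once this further centre is inverted, since the full path gives a number 4.2 percentage points lower from compound 1 to compound 3 (within the scatter) and leaves compound 1 and compound 3 without a readable difference, although three of their four stereo elements differ.

Which of the two inversions separating compound 1 from compound 2 carried the rise remains open, as does whether either of them would have any effect alone. As far as these compounds go, it is equally open how a hydroxymethyl group or a primary amide in place of the carboxylic acid would read on the configuration of compound 2.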